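Swapping the Amide Substituent on a Weak Phosphatase Inhibitor

This account rests on a few compounds, and the source may have more. Where it says the series, first, only, none or still open, it means among the compounds named here.

All the compounds here were tested in an assay on isolated protein for inhibition of receptor-type tyrosine-protein phosphatase C (Homo sapiens), read by spectrophotometry; on this read-out lower numbers stand for stronger inhibition and higher numbers for weaker inhibition. Two small fragments set the scene. Compound 1 `Oc1cc(-c2ccccc2)ccc1C(O)(C(F)(F)F)C(F)(F)F` reaches only a limit of the assay, > 500000 nM. Compound 2 `Oc1c(-c2ccccc2)cccc1C(O)(C(F)(F)F)C(F)(F)F` gives a measurable but feeble 157000 nM. Compound 3 `COc1ccc(CNC(=O)COc2ccc3cc(C(O)(C(F)(F)F)C(F)(F)F)c(O)cc3c2)cc1OC` is a larger molecule built on the same phenol and fluorinated alcohol pair, extended through an ether-linked amide. In this assay compound 3 also reaches only a limit, > 20000 nM. Compound 3 thus stands at the limit of > 20000 nM in this assay, at which 1 of the 3 values shown sits, and nothing in the data places it on a number; it is simply too weak to be read.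

For the measured compounds named here, compound 4 `O=C(COc1ccc2cc(C(O)(C(F)(F)F)C(F)(F)F)c(O)cc2c1)Nc1ccc(-c2ccccc2)cc1` is the single change from compound 3: 4-phenylphenyl in place of 3,4-dimethoxybenzyl on an amide-type nitrogen. Going by the values given here, no pair of measured compounds shows how such a swap behaves in this assay, so there is no step to lean on. Given that compound 3 sits at > 20000 nM, the expectation for compound 4 is a result in the same weak region, with a real chance that the assay again reports only a limit. In this assay compound 4 is estimated at 30000 nM, within a range of 8000 nM to 150000 nM. This expected estimate corresponds to a step that the limit leaves unreadable from compound 3 to compound 4, a step not confidently beyond the scatter.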

Compound 4, half-maximal inhibitory concentration: 3400 nM
Compound 4: the middle estimate sits 8.8-fold (0.95 log units) above what was measured; measured number outside the range, below it.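

In this assay, for the compounds shown here, the amide nitrogen proves to be a place where the choice of substituent matters: 4-phenylphenyl in place of 3,4-dimethoxybenzyl gives an at least 5.8-fold lower number from compound 3 to compound 4 (0.76 log units; beyond the scatter), the only step between compounds differing in one place that can be read here. Going by these compounds alone, the change also shows that this larger scaffold can give a readable number, which its one earlier member, with 3,4-dimethoxybenzyl on the nitrogen, did not. The step is only a minimum, and its true size stays unknown, because compound 3 rests on a limit of the assay rather than on a number: the limit of > 20000 nM in this assay, at which 1 of the 4 values shown sits.

The swap changes several things at once, including the number of aromatic rings and of hydrogen-bond acceptors, and these compounds cannot separate those changes from one another. From the compounds shown here alone, whether a plain phenyl on the same nitrogen, or a 4-phenylphenyl group carrying a carboxylic acid, would keep, lose or extend this gain also remains open.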